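This account rests on a few compounds, and the source may have more. Where it says the series, first, only, none or still open, it means among the compounds named here.

Compound 3 `Cc1ccc(NC(=S)NC(=O)c2ccc(OCc3ccccc3Cl)cc2)cc1-c1nc2ccccc2[nH]1` was tested in a functional assay on SW-620 cells (Homo sapiens) for inhibition, read by MTT assay, with a stated time of 48 h (a lower number here means a stronger inhibitor, a higher number a weaker inhibitor), where compound 3 gives 57100 nM. Compound 1 `Cc1ccc(NC(=S)NC(=O)c2ccc(OCc3cccc(Cl)c3)cc2)cc1-c1nc2ccccc2[nH]1` gives only a limit in this assay, > 100000 nM. Compound 2 `Cc1ccc(NC(=S)NC(=O)c2ccc(OCc3cccc(C(F)(F)F)c3)cc2)cc1-c1nc2ccccc2[nH]1` gives 15400 nM in this assay. Of the two numbers shown, compound 3 holds the higher one, seen in a 3.7-fold higher number from compound 2 to compound 3 (0.57 log units; beyond the scatter); the step of an at least 1.7-fold lower number from compound 1 to compound 3 (0.24 log units; that floor lies within the scatter) rests on a limit. Compound 4 `Cc1ccc(NC(=S)NC(=O)c2ccc(OCc3ccc(F)cc3)cc2)cc1-c1nc2ccccc2[nH]1` differs from compound 3 by 4-fluorophenyl in place of 2-chlorophenyl on a saturated chain carbon bound to an oxygen on an aromatic ring. Both measured steps exchange the group on a saturated chain carbon bound to an oxygen on an aromatic ring, one modest and one within the scatter, so the new exchange is expected to give at most a small step, a 1.1-fold lower number from compound 3 to compound 4 (0.06 log units; within the scatter). For compound 4 the expected value is 50000 nM, with a range from 15000 nM to 150000 nM.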

Compound 4, half-maximal inhibitory concentration: 40500 nM
Estimate against measurement, compound 4: 1.2-fold (0.09 log units) above; low and high end bracket the measured number.
By their numbers in this assay, from the lowest: compound 2; then compounds 4 and 3 (each within the scatter of the next). At a limit, above all of these: compound 1.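

In this assay, 4-fluorophenyl on a saturated chain carbon bound to an oxygen on an aromatic ring stands level with 2-chlorophenyl, a 1.4-fold lower number from compound 3 to compound 4 (0.15 log units; within the scatter). It does not reach 3-(trifluoromethyl)phenyl, a 2.6-fold higher number from compound 2 to compound 4 (0.42 log units; beyond the scatter), so trifluoromethyl keeps its lead over both of these halogen-bearing rings. A further step, an at least 2.4-fold lower number from compound 1 to compound 4 (0.39 log units; beyond the scatter), clears the scatter, but it rests on a limit: the limit of > 100000 nM in this assay, at which 1 of the 4 values shown sits.

The compounds shown leave open whether trifluoromethyl itself matters here or any larger group would serve as well. As far as these compounds go, how a plain phenyl, a methoxyphenyl or a pyridine ring would read in this place also remains open.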